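Swapping methoxy for dimethylamino on compound 2

This account rests on a few compounds, and the source may have more. Where it says the series, first, only, none or still open, it means among the compounds named here.

compound 1 `CN(C)c1ccc2c(c1)OC(N)=C(C#N)C2c1cccc2c(F)cccc12` gives 130 nM
compound 2 `COc1ccc(C2C(C#N)=C(N)Oc3cc(N(C)C)ccc32)c2ccccc12` gives 440 nM

In a functional assay on A-375 cells (Homo sapiens) for antiproliferative activity, read by sulforhodamine B assay, with a stated time of 48 h (a higher number here means a weaker inhibitor, a lower number a stronger inhibitor), compound 2 has the higher of the two numbers (440 nM) and is the weaker inhibitor of the two measured compounds. Compound 3 `CN(C)c1ccc2c(c1)OC(N)=C(C#N)C2c1ccc(N(C)C)c2ccccc12` differs from it by a single change (dimethylamino in place of methoxy on an aromatic carbon) with dimethylamino in place of methoxy on an aromatic carbon. Within the data shown here, no measured pair shows this change, so there is little to go on. The estimated step (a 1.1-fold lower number from compound 2 to compound 3 (0.04 log units; within the scatter)) is expected to stay within the scatter, in neither direction. For compound 3 the estimated value is 400 nM (expected range 120 nM to 1300 nM).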

Compound 3, half-maximal inhibitory concentration: 80 nM
Compound 3: the middle estimate sits 5.0-fold (0.70 log units) above what was measured, and the stated range ends above it.
By their numbers in this assay, from the lowest: compounds 3 and 1 (each within the scatter of the next); then compound 2.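

Among these compounds, the change of methoxy to dimethylamino, on the aromatic carbon para to a large group, brings a 5.5-fold lower number from compound 2 to compound 3 (0.74 log units; beyond the scatter) in this assay and so gives the first direct reading at this position. This carbon is therefore not indifferent to the group it carries, at least in this one pair. No available data explain the difference.

Going by these compounds, whether the same change would have a similar effect on another core remains open. So does how a smaller amine, such as methylamino, or a longer chain, such as ethoxy, would behave at this position.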